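This account rests on a few compounds, and the source may have more. Where it says the series, first, only, none or still open, it means among the compounds named here.

Three compounds built on a shared core, each carrying a chain that ends in an amine, have been tested in an assay on isolated protein (Cavia porcellus) with Sigma non-opioid intracellular receptor 1 (Homo sapiens) as the target, read by radioligand binding; on this read-out higher numbers stand for weaker inhibition and lower numbers for stronger inhibition. Compound 1 `O=c1cc(-c2ccccc2)oc2ccc(OCCCCCCN3CCC(O)CC3)cc12` gives 121 nM. Compound 2 `O=c1cc(-c2ccccc2)oc2ccc(OCCCCCCN3CCCC(O)C3)cc12` gives 77 nM. Compound 3 `CN(CCCCCCOc1ccc2oc(-c3ccccc3)cc(=O)c2c1)Cc1ccccc1` gives 75 nM. Compound 3 has the lowest of the three numbers, but the gaps to the other two are small: a 1.6-fold lower number from compound 1 to compound 3 (0.21 log units; within the scatter) and a 1.0-fold lower number from compound 2 to compound 3 (0.01 log units; within the scatter), so none of the three can be told apart on these numbers. The remaining step, a 1.6-fold lower number from compound 1 to compound 2 (0.20 log units; within the scatter), is small as well. Each of these changes exchanged only the group at the end of the chain, and each left the number in this assay essentially where it was.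

Compound 4 `CCOC(=O)C1CCN(CCCCCCOc2ccc3oc(-c4ccccc4)cc(=O)c3c2)CC1` continues the same pattern of exchange: 4-(ethoxycarbonyl)piperidin-1-yl in place of benzyl(methyl)amino on a saturated chain carbon, six bonds along the chain from an oxygen on an aromatic ring. The measured steps bear on it directly, since each also replaced the group at this same position on the chain: a 1.6-fold lower number from compound 1 to compound 3 (0.21 log units; within the scatter), a 1.0-fold lower number from compound 2 to compound 3 (0.01 log units; within the scatter) and a 1.6-fold lower number from compound 1 to compound 2 (0.20 log units; within the scatter), all within the scatter. No step beyond the scatter is therefore expected from compound 3 to compound 4 in this assay. The estimate for compound 4 is 90 nM, with a range from 35 nM to 250 nM, which amounts to an expected step of a 1.2-fold higher number from compound 3 to compound 4 (0.08 log units; within the scatter).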

Compound 4, half-maximal inhibitory concentration: 102 nM
For compound 4 the middle estimate is 1.1-fold (0.05 log units) below the measured one, within the range that was stated.
By their numbers in this assay, from the lowest: compounds 3, 2, 4 and 1 (each within the scatter of the next).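

In this assay, a larger group carrying an ester can sit at the end of the chain without moving the number beyond the scatter: the exchange for benzyl(methyl)amino gives a 1.4-fold higher number from compound 3 to compound 4 (0.13 log units; within the scatter), and the exchange for 3-hydroxypiperidin-1-yl gives a 1.3-fold higher number from compound 2 to compound 4 (0.12 log units; within the scatter). The comparison with compound 1 is new in kind, since the piperidine ring stays in place and only the group on its saturated ring carbon differs, with ethoxycarbonyl in place of hydroxy giving a 1.2-fold lower number from compound 1 to compound 4 (0.07 log units; within the scatter). All four compounds therefore remain indistinguishable in this assay, and nothing available explains this insensitivity to the end group.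

These compounds leave open whether any end group at this position would produce a step beyond the scatter, for example a carboxylic acid in place of the ethoxycarbonyl or a primary amine in place of the piperidine ring. They also leave open whether a shorter or longer chain would change the number, since every compound here keeps the same chain length.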